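The source may report more compounds than this note shows. Statements on the series, on what has been measured and on what is new or still open speak of the compounds shown alone.

Measured so far:
compound 1 `Clc1cccc(/N=N/N2CCCC2)c1`: >= 100000 nM
compound 2 `c1ccc(/N=N/N2CCCCC2)cc1`: > 100000 nM
compound 3 `Clc1ccc(/N=N/N2CCCC2)cc1Cl`: 58000 nM

In an ADME assay on Vero cells (Chlorocebus sabaeus) for cytotoxicity, read by crystal violet staining (on this read-out lower numbers stand for higher toxicity in this test and higher numbers for lower toxicity in this test), compound 1 reaches only a limit, >= 100000 nM. Compound 2 likewise stops at a limit, > 100000 nM. Compound 3 gives a number, 58000 nM. The step of an at least 1.7-fold lower number from compound 1 to compound 3 (0.23 log units; that floor lies within the scatter) follows the change (chloro in place of hydrogen on an aromatic carbon). How the core of compound 2 differs from that of compound 1 is not broken down here. Compound 4 `Clc1ccc(/N=N/N2CCCCC2)cc1` awaits measurement in this assay; it differs from compound 2 by chloro in place of hydrogen on an aromatic carbon, the same kind of change, though the place differs: in compound 3 the entering chloro sits ortho to a chloro group and para to a group of 7 heavy atoms, in compound 4 para to a group of 8 heavy atoms. Resting on the step from compound 1 to compound 3, compound 4 is expected to move by an at least 1.1-fold lower number from compound 2 to compound 4 (0.04 log units; that floor lies within the scatter), giving an estimated 90000 nM, from 40000 nM to 200000 nM.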

Compound 4, half-maximal cytotoxic concentration: > 100000 nM
Compound 4: only a limit was reported; the forecaster's own chance of this, stated with the estimate: 50%; middle value at least 1.1-fold (0.04 log units) away from the limit.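

In this assay, within the data shown here, compound 2 and compound 4 both stop at a limit, so no step between them can be read. The compounds shown leave open whether chloro in place of hydrogen on an aromatic carbon changes the number on this core at all.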